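Adding an isopropoxy group to compound 2

The source may report more compounds than this note shows. Statements on the series, on what has been measured and on what is new or still open speak of the compounds shown alone.

In an ADME assay on HT-29 cells (Homo sapiens) for cytotoxicity, read by MTT assay, with a stated time of 72 h (on this read-out lower numbers stand for stronger inhibition and higher numbers for weaker inhibition), compound 1 `COc1ccc(C2=C(c3cc(OC)c(OC)c(OC)c3)C(=O)C(OC(C)=O)C2)cc1` gives < 1 ug/mL, which is a limit. Compound 2 `COc1ccc(C2=C(c3cc(OC)c(OC)c(OC)c3)C(=O)C(O)C2)cc1` gives < 1 ug/mL, also a limit and not a number. Among the measured compounds shown here, the one measured step is a step that the two limits leave unreadable from compound 1 to compound 2, and it lies at a different place from the next change. Compound 3 `COc1ccc(C2=C(c3cc(OC)c(OC)c(OC)c3)C(=O)C(O)C2)cc1OC(C)C` carries isopropoxy in place of hydrogen on an aromatic carbon, with isopropoxy in place of hydrogen on an aromatic carbon, ortho to a methoxy group. For the measured compounds named here, no measured step bears on this change, so no direction is expected. The estimated step is a step that the limit leaves unreadable from compound 2 to compound 3. For compound 3 the expected value is 0.5 ug/mL, within an estimated range of 0.08 ug/mL to 3 ug/mL.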

Compound 3, half-maximal inhibitory concentration: > 100 ug/mL
Compound 3 gave a limit, no number; the forecaster's own chance of this, stated with the estimate: 60%; middle value at least 200-fold (2.30 log units) from the limit.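

Isopropoxy in place of hydrogen on this aromatic carbon, ortho to a methoxy group, gives an at least 100-fold higher number from compound 2 to compound 3 (2.00 log units; beyond the scatter), the first step in the series that can be read. Among the compounds shown here, the earlier step, at the oxygen on the saturated carbon, cannot be read, so this is the first sign that a change to the shared core can cost much of the inhibition. The value of compound 3 is a limit and not a number.

From the compounds shown here alone, whether a hydroxy group, an ethoxy group or an amine at this place would cost as much stays open. So does whether the same change would weaken compound 1.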